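Agonist read-out at the receptor for compounds 2 and 3

The source may report more compounds than this note shows. Statements on the series, on what has been measured and on what is new or still open speak of the compounds shown alone.

Compound 2 `c1ccc2c(c1)CN[C@@H](CN(CCCCNCc1ccncc1)[C@H]1CCCc3cccnc31)C2` and compound 1 `c1cncc(CN(CCCCN(C[C@H]2Cc3ccccc3CN2)[C@H]2CCCc3cccnc32)Cc2cccnc2)c1` share a core. In a functional assay on cells for agonist activity at C-X-C chemokine receptor type 4 (Homo sapiens), read by fluorescence and calcium flux, with a stated time of 90 s (on this read-out higher numbers stand for an effect only at larger amounts of compound and lower numbers for an effect already at smaller amounts), compound 2 gives only a limit, > 30000 nM. Compound 1 likewise sits at a limit in this assay, > 30000 nM. Compound 2 thus stands where every shown value sits, at the limit of > 30000 nM in this assay, at which 2 of the 2 values shown sit. Compound 3 `C(=C/CN(C[C@H]1Cc2ccccc2CN1)[C@H]1CCCc2cccnc21)\CNC1CCOCC1` carries 3-((oxan-4-yl)amino)prop-1-en-1-yl in place of 3-(((pyridin-4-yl)methyl)amino)propyl on a saturated chain carbon bound to an amine nitrogen. For the measured compounds named here, no measured step is available to size this change, and no shift beyond the scatter is expected in this assay. The estimated step of a number no higher from compound 2 to compound 3 (the limit leaves the size open) is accordingly flat. Compound 3 is expected at 30000 nM, between 10000 nM and 30000 nM, most likely again reported only as a limit.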

Compound 3, half-maximal effective concentration: > 30000 nM
Compound 3: a limit, no number; the forecaster's own chance of this, stated with the estimate: 90%; the middle value lies on the limit itself.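

Compound 2 and compound 3 both stand at a limit in this assay, and no step between them can be read: the limit of > 30000 nM in this assay, at which 3 of the 3 values shown sit.

The compounds shown leave open whether 3-((oxan-4-yl)amino)prop-1-en-1-yl in place of 3-(((pyridin-4-yl)methyl)amino)propyl shifts the read-out at all.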